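Amino for dimethylamino on the core of compound 2

The compounds below may be only part of what the source reports. "The series", "measured", "known", "first", "only" and "open" are said of these compounds alone.

Measured so far in a functional assay on HeLa cells (Homo sapiens) for antiproliferative activity, read by sulforhodamine B assay, with a stated time of 72 h (a lower number here means a stronger inhibitor, a higher number a weaker inhibitor), are three compounds:
compound 1 `COc1ccccc1NC(=S)N/N=C/c1ccc2ccccc2n1` gives > 100000 nM as a limit
compound 2 `CN(C)C(=S)N/N=C/c1ccc2cccnc2n1` gives 970 nM as a number
compound 3 `Cc1cccc(NC(=S)N/N=C/c2ccc3ccccc3n2)c1` gives > 100000 nM as a limit

Among the compounds with values here, compound 2 gives 970 nM as the only true number in the set. The other two values are limits, so compound 2 cannot be placed on a scale against them by any measured distance.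

The next compound is compound 4 `NC(=S)N/N=C/c1ccc2cccnc2n1` which keeps the core of compound 2 and carries amino in place of dimethylamino on a thiocarbonyl carbon. The change counts as amino in place of dimethylamino on a thiocarbonyl carbon and nothing else in the structure differs.

Within the data shown here, the one measured step is a step that the two limits leave unreadable from compound 1 to compound 3 and it gives no size to carry over, since it lies at another place in the structure. Among the measured compounds shown here, the only lean comes from compound 1 and compound 3, which lack dimethylamino and stand at the limit of > 100000 nM in this assay, at which 2 of the 3 values shown sit, on a core that differs from that of compound 2. This is thin support and no pattern. A weaker value is nevertheless expected, with an estimated 4.1-fold higher number from compound 2 to compound 4 (0.62 log units; beyond the scatter) on this basis. In this assay the expected value for compound 4 is 4000 nM with an estimated range of 600 nM to 30000 nM as a wide margin.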

Compound 4, half-maximal inhibitory concentration: > 100000 nM
Compound 4: a limit, no number; the forecaster's own chance of this, stated with the estimate: 12%; middle value at least 25-fold (1.39 log units) from the limit.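

In this assay, within the data shown here, the group on the thiocarbonyl carbon of the shared core turns out to be a sensitive position: amino in place of dimethylamino gives an at least 100-fold higher number from compound 2 to compound 4 (2.01 log units; beyond the scatter), the first step with a readable size, and a large one. Compound 4 gives > 100000 nM, which is a limit and not a number, so the step has a floor and no upper end. The dimethylamino compound now holds the only true number in the set, while the other three compounds share one limit: the limit of > 100000 nM in this assay, at which 3 of the 4 values shown sit.

On these data alone, whether a number returns with methylamino, diethylamino or a cyclic amine such as morpholine on the thiocarbonyl carbon remains open, so the two compounds on this core mark only two points at this position and do not show how much of the group is needed. Also open, as far as these compounds go, is whether dimethylamino on the core of compound 1, in place of the substituted phenylamino groups carried there, would lift that core off the limit, since no single-place comparison connects the two cores.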